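This account rests on a few compounds, and the source may have more. Where it says the series, first, only, none or still open, it means among the compounds named here.

Compound 1 `CC/C(=C\C(=N\O)C(N)=O)C(CC)[N+](=O)[O-]` gives in an ADME assay for pharmacokinetics (on this read-out lower numbers stand for a shorter-lived compound and higher numbers for a longer-lived compound), a value of 2.5 h. Compound 2 `CC/C(=C\C(=N\O)C(N)=O)C(C(C)C)[N+](=O)[O-]` carries methyl in place of hydrogen on a saturated chain carbon bound to two saturated chain carbons and in this assay compound 2 gives 11.5 h, so that a 4.6-fold higher number from compound 1 to compound 2 (0.66 log units; beyond the scatter) is the single reference point for this change. Compound 3 `CC/C(=C\C(CNC(=O)c1cccnc1)=N\O)C(CC)[N+](=O)[O-]` keeps the 1-nitropropyl group but differs from compound 1 elsewhere; the difference between the two cores is not broken down here. In this assay compound 3 gives 5.83 h. Compound 4 `CC/C(=C\C(CNC(=O)c1cccnc1)=N\O)C(C(C)C)[N+](=O)[O-]` carries the same change relative to compound 3, namely (methyl in place of hydrogen on a saturated chain carbon bound to two saturated chain carbons), at the same place. The step from compound 3 to compound 4 is expected to be a 2.9-fold higher number from compound 3 to compound 4 (0.46 log units; beyond the scatter), set a little smaller than the reference step since a 4.6-fold higher number from compound 1 to compound 2 (0.66 log units; beyond the scatter) rests on one pair only and may not transfer in full to a different core. For compound 4 the expected value in this assay is 17 h, within 8 h to 38 h.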

Compound 4, half-life: 30 h
Compound 4: middle estimate off by 1.8-fold (0.25 log units), on the low side; low and high end bracket the measured number.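

In this assay, methyl in place of hydrogen on a saturated chain carbon bound to two saturated chain carbons again goes with a 5.1-fold higher number from compound 3 to compound 4 (0.71 log units; beyond the scatter), so the change carries over to the core of compound 3 at undiminished size. The two cores agree on this step: the same change on two cores in this assay, a 4.6-fold higher number (0.66 log units; beyond the scatter) from compound 1 to compound 2 and a 5.1-fold higher number (0.71 log units; beyond the scatter) from compound 3 to compound 4, 1.1-fold (0.05 log units) apart, within the scatter of two such steps This agreement rests on two pairs only, both with the same change at the same place, and shows neither how the change behaves on other cores nor why the number rises.

Still open, from the compounds shown here alone, is whether a longer chain such as butyl, or a cyclopropyl group, at this place gives a step of similar size. Also open, going by these compounds, is whether the step survives with a carboxylic acid on the core.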